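A few compounds are considered here, and "the series" means these few. Any claim that something is new, unique, unknown or untested is made for them only; others in the source may bear on it.

Compound 1 `O=S(=O)(Nc1ccccc1NS(=O)(=O)c1ccc(F)cc1)c1ccccc1` gives 13900 nM in an assay for binding affinity to protein lin-28 homolog A (Mus musculus), with a stated time of 1 h; a higher number here means a weaker inhibitor, a lower number a stronger inhibitor. Compound 2 `O=S(=O)(Nc1ccccc1NS(=O)(=O)c1ccc(F)cc1)c1ccc(F)cc1` carries fluoro in place of hydrogen on an aromatic carbon and in this assay gives 28300 nM, which makes a 2.0-fold higher number from compound 1 to compound 2 (0.31 log units; beyond the scatter). Compound 3 `Cc1ccc(S(=O)(=O)Nc2ccccc2NS(=O)(=O)c2ccc(C)c(Cl)c2)cc1Cl` rests on a different core; the difference between the two cores is not broken down here. In this assay compound 3 gives 2300 nM. Compound 4 `Cc1ccc(S(=O)(=O)Nc2ccc(F)cc2NS(=O)(=O)c2ccc(C)c(Cl)c2)cc1Cl` differs from compound 3 by fluoro in place of hydrogen on an aromatic carbon. This is the same kind of change as that between compound 1 and compound 2, though not the same: here the entering group sits meta to a large group as well as para to a large group, whereas before it sat only para to a large group. Because the earlier step was a 2.0-fold higher number from compound 1 to compound 2 (0.31 log units; beyond the scatter), the expected step here is a 1.7-fold higher number from compound 3 to compound 4 (0.22 log units; within the scatter). Compound 4 is therefore estimated at 3800 nM in this assay, within a range from 1500 nM to 10000 nM.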

Compound 4, half-maximal inhibitory concentration: 3700 nM
For compound 4 the middle estimate is 1.0-fold (0.01 log units) above the measured one; the measured number falls inside the stated range.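

In this assay, fluoro in place of hydrogen on an aromatic carbon gives a 1.6-fold higher number from compound 3 to compound 4 (0.21 log units; within the scatter), and this step matches the earlier one on the other core: the same change on two cores in this assay, a 2.0-fold higher number (0.31 log units; beyond the scatter) from compound 1 to compound 2 and a 1.6-fold higher number (0.21 log units; within the scatter) from compound 3 to compound 4, 1.3-fold (0.10 log units) apart, within the scatter of two such steps. The change thus carried over between these two cores without a discernible difference in size, although here the entering group sits meta to a large group as well as para to a large group. Two pairs set no rule for other cores or other ring places, however, and the new step, lying within the scatter, does not separate compound 4 from compound 3.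

The compounds shown leave open how other groups would behave at this place, such as a methoxy group, an amine or a carboxylic acid. As far as these compounds go, whether a nitrile or bromo would follow the same course on both cores also remains open.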